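Replacing a Formyl Group on the Phenol Ring

The source may report more compounds than this note shows. Statements on the series, on what has been measured and on what is new or still open speak of the compounds shown alone.

Measured in a functional assay on NALM-6 cells (Homo sapiens) for cytotoxicity, with a stated time of 72 h (a lower number here means that less compound is needed, a higher number that more compound is needed for the effect), so far:
Compound 1 (`C=C[C@@](C)(/C=C/c1ccc(O)cc1)CCC=O`) gives > 43400 nM (a limit)
Compound 2 (`C=C[C@@](C)(/C=C/c1ccc(O)cc1)CC/C=C(C)/C=N/N`) gives > 43400 nM (a limit)
Compound 3 (`C=C[C@@](C)(/C=C/c1ccc(O)c(C=O)c1)CCC=C(C)C`) gives 11200 nM (a number)

Among the measured compounds shown here, compound 3 stands at 11200 nM and carries the only number in the set. Compound 1 and compound 2 offer only the limit of > 43400 nM in this assay, at which 2 of the 3 values shown sit, and no number. Compound 4 (`C=C[C@@](C)(/C=C/c1ccc(O)c(/C=C/C#N)c1)CCC=C(C)C`) departs from compound 3 by 2-cyanoethenyl in place of formyl on an aromatic carbon in one place: 2-cyanoethenyl in place of formyl on an aromatic carbon, ortho to a hydroxy group. For the measured compounds named here, the sole measured step that the two limits leave unreadable from compound 1 to compound 2 has no readable size and sits on a saturated chain carbon, so it does not bear on this change. No measured step therefore sizes the swap, and nothing shown fixes a direction in this assay for it. The expectation is thus for little movement beyond the scatter, held with a wide margin. The estimate is a 1.2-fold lower number from compound 3 to compound 4 (0.09 log units; within the scatter) and it remains only an expectation. Compound 4 is expected at 9000 nM (estimated range 3000 nM to 30000 nM).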

Compound 4, half-maximal effective concentration: > 43400 nM
Compound 4 ended at the assay's limit (the forecaster's own chance of this, stated with the estimate: 15%); middle value at least 4.8-fold (0.68 log units) from the limit.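

In this assay, among the compounds shown here, putting 2-cyanoethenyl in place of formyl on an aromatic carbon, ortho to a hydroxy group, gives an at least 3.8-fold higher number from compound 3 to compound 4 (0.58 log units; beyond the scatter); this is the only readable step in the set, since the step between the two earlier limits cannot be read. It shows that this position responds to the choice of group, and that this replacement moves the result beyond the scatter, toward more compound being needed. Compound 3 remains the only compound with a number, which leaves the size of the step open on one side: the limit of > 43400 nM in this assay, at which 3 of the 4 values shown sit.

With a single replacement at this position, the compounds shown do not tell whether a smaller or a different group, such as an amine, a carboxylic acid or a hydroxymethyl group, would keep a number in this assay. They also give no cause for the step.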